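Two Thiosemicarbazones Measured, a Third Estimated

The compounds below may be only part of what the source reports. "The series", "measured", "known", "first", "only" and "open" are said of these compounds alone.

In a functional assay on UACC-62 cells (Homo sapiens) for cytotoxicity, read by sulforhodamine B assay (a higher number here means a weaker inhibitor of growth, a lower number a stronger inhibitor of growth), the measured compounds are:
compound 1 `CC1=CC[C@@H]([C@@](C)(O)CCCC(C)(C)NC(=S)N/N=C\c2ccccc2Cl)CC1`: 53300 nM
compound 2 `CC1=CC[C@@H]([C@@](C)(O)CCCC(C)(C)NC(=S)N/N=C\c2cccc(Cl)c2)CC1`: 7810 nM

Within the data shown here, compound 2 gives the lower of the two numbers; the single measured step, a 6.8-fold lower number from compound 1 to compound 2 (0.83 log units; beyond the scatter), separates them. Compound 3 `CC1=CC[C@@H]([C@@](C)(O)CCCC(C)(C)NC(=S)N/N=C(/C)c2ccccc2)CC1` differs from compound 2 by a group of 9 heavy atoms (8 carbon, 1 nitrogen; one six-membered aromatic ring of carbon only) in place of a group of 9 heavy atoms (7 carbon, 1 nitrogen, 1 chlorine; one six-membered aromatic ring of carbon only), on an amide-type nitrogen. Among the measured compounds shown here, no measured step covers loss of the chlorine or the added carbon on the imine carbon; the one step shows only that the chlorine's position shifts the number. With the chlorine gone, compound 3 is expected to give a higher number than compound 2, but of uncertain size. The estimate for compound 3 is 20000 nM (range 5000 nM to 80000 nM), an expected step of a 2.6-fold higher number from compound 2 to compound 3 (0.41 log units; beyond the scatter).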

Compound 3, concentration for 50% growth inhibition: 22400 nM
For compound 3 the middle estimate is 1.1-fold (0.05 log units) below the measured one; the range from low to high includes it.
By their numbers in this assay, from the lowest: compound 2; then compound 3; then compound 1.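

In this assay, the group with 8 carbon and no chlorine on the amide-type nitrogen does not fall outside the span of the two chlorinated compounds: the number rises (a 2.9-fold higher number from compound 2 to compound 3 (0.46 log units; beyond the scatter)) against one and falls (a 2.4-fold lower number from compound 1 to compound 3 (0.38 log units; beyond the scatter)) against the other. Losing the chlorine therefore has no single direction here, and its result depends on which chlorinated compound is the reference. No measurement offered here explains either step.

The compounds shown leave open how much of either step belongs to the lost chlorine and how much to the added carbon on the imine carbon. They also leave open how a methoxy group or a bromine on the aromatic ring would read.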